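Ethyl for Methyl on the Carboxy Analogue of Compound 3

The compounds below may be only part of what the source reports. "The series", "measured", "known", "first", "only" and "open" are said of these compounds alone.

Measured compounds:
compound 1 `Cc1ccc2nc(C(=O)Nc3c(F)cc(-c4cccc(F)c4)cc3F)c(C)c(O)c2c1`, in a functional assay on Hep 3B2 cells (Homo sapiens) for antiproliferative activity, read by MTT assay, with a stated time of 24 h, tested at 0.14 ug/mL (on this read-out lower numbers stand for a weaker effect and higher numbers for a stronger effect at the one concentration tested), giving 2.34%
compound 2 `CCc1ccc2nc(C(=O)Nc3c(F)cc(-c4cccc(F)c4)cc3F)c(C)c(O)c2c1`, giving 11.2%
compound 3 `Cc1ccc2nc(C(=O)Nc3c(F)cc(-c4cccc(F)c4)cc3F)c(C)c(C(=O)O)c2c1`, giving 6.34%

Compound 3 stands second highest of these three numbers, though all three lie within the scatter of one another. The nearest step to it is a number 4 percentage points higher from compound 1 to compound 3 (within the scatter), and the furthest number is that of compound 2, which is separated from compound 3 by a gap that is likewise within the scatter.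

Compound 4 `CCc1ccc2nc(C(=O)Nc3c(F)cc(-c4cccc(F)c4)cc3F)c(C)c(C(=O)O)c2c1` differs from compound 3 in one place: methyl in place of hydrogen on a saturated chain carbon bound to an aromatic carbon. For the measured compounds named here, the one measured step that bears on this change is a number 8.9 percentage points higher from compound 1 to compound 2 (within the scatter), where the same change was made on the pair carrying hydroxy instead of carboxy. That step stayed within the scatter, and nothing else in the set speaks to the change. The expectation is therefore a step of about a number 5.7 percentage points higher from compound 3 to compound 4 (within the scatter), leaning upward but not clearly beyond the scatter. Compound 4 is estimated at 12%, with a range from 0% to 24%.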

Compound 4, a percentage reported as inhibition, at one concentration (the size of the read-out at that concentration, not a potency): 0.68%
Compound 4: middle estimate off by 11.3 percentage points, on the high side; the range from low to high includes it.
By their numbers in this assay, from the lowest: compounds 4, 1, 3 and 2 (each within the scatter of the next, the first and the last beyond it).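

In this assay, methyl in place of hydrogen on a saturated chain carbon bound to an aromatic carbon gives a number 5.7 percentage points lower from compound 3 to compound 4 (within the scatter), so the step seen on the hydroxy pair does not carry over to the carboxy pair: the same change on two cores in this assay, a number 8.9 percentage points higher (within the scatter) from compound 1 to compound 2 and a number 5.7 percentage points lower (within the scatter) from compound 3 to compound 4, 14.5 percentage points apart, beyond the scatter of two such steps

Carboxy in place of hydroxy on an aromatic carbon, now with ethyl in place of methyl, gives a number 10.5 percentage points lower from compound 2 to compound 4 (beyond the scatter), which also departs from the matching step with methyl: the same change on two cores in this assay, a number 4 percentage points higher (within the scatter) from compound 1 to compound 3 and a number 10.5 percentage points lower (beyond the scatter) from compound 2 to compound 4, 14.5 percentage points apart, beyond the scatter of two such steps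

In these four compounds the two changes therefore do not simply add, and each step depends on which group the other place carries.

From the compounds shown here alone, whether this dependence extends to a longer chain such as propyl, or to an amine or methoxy in place of hydroxy or carboxy, remains open. All four numbers also come from a single concentration, so they give no potencies.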